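The source may report more compounds than this note shows. Statements on the series, on what has been measured and on what is new or still open speak of the compounds shown alone.

Measured so far:
- compound 1, `CN(/N=N/c1ccc(C(N)=O)cc1)c1cccs1`: 2.9
- compound 2, `CCCCCN(C)/N=N/c1nc[nH]c1C(N)=O`: 3.58

In a functional assay on L1210 cells (Mus musculus) for antiproliferative activity (a lower number here means a less potent compound, a higher number a more potent compound, by a factor of ten per unit of this negative logarithm), compound 2 stands highest of the two numbers; the nearest is compound 1, whose value lies lower by a gap beyond the scatter. For the measured compounds named here, compound 1 and compound 2 differ in more than one place, so no single step between them is counted.

Compound 3, `CN(/N=N/c1nc[nH]c1C(N)=O)c1cccs1`, is not yet measured. It differs from compound 2 by thiophen-2-yl in place of pentyl on an amine nitrogen. Going by the values given here, no measured pair shows this same change, so its size is not known from this series. Compound 1 carries the same thiophen-2-yl on a different core and gives 2.9, which points toward a lower value rather than a higher one. A moderate downward step is therefore expected, a number 0.28 log units lower from compound 2 to compound 3 (within the scatter), though a result within the scatter would not surprise. The expected value for compound 3 in this assay is 3.3, with a range from 2.7 to 3.9.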

Compound 3, logarithm of the reciprocal of the active concentration, log(1/C): 3.87
For compound 3 the middle estimate is 0.57 log units below the measured one, and the stated range covers the measured number.
By their numbers in this assay, from the lowest: compound 1; then compounds 2 and 3 (each within the scatter of the next).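

In this assay, for the compounds shown here, the first direct reading of this change gives a number 0.29 log units higher from compound 2 to compound 3 (within the scatter), so on the shared core the amine nitrogen carries thiophen-2-yl and pentyl with no separation between the two groups. The position therefore holds an aromatic five-membered ring as well as a saturated chain of the same heavy-atom count, and the swap alone leaves the read-out within the scatter. No supporting measurement is available to explain this result.

From the compounds shown here alone, only these two groups have been compared at this position, so it remains open whether the result extends to a phenyl ring, a furan-2-yl ring or a longer chain such as octyl. A chain ending in a hydroxyl group or an amine also remains untested in the compounds shown.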